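A few compounds are considered here, and "the series" means these few. Any claim that something is new, unique, unknown or untested is made for them only; others in the source may bear on it.

Measured so far:
Compound 1 `O=c1c(-c2nn[nH]n2)c[nH]c2ccccc12`: in a functional assay on the whole organism (strain Sprague-Dawley) for inhibition, with Rattus norvegicus as the target (on this read-out higher numbers stand for an effect only at larger amounts of compound and lower numbers for an effect already at smaller amounts), compound 1 gives only a limit, > 20 mg/kg.
Compound 2 `Cc1ccc2[nH]cc(-c3nn[nH]n3)c(=O)c2c1`: in this assay compound 2 gives only a limit, > 25 mg/kg.
Compound 3 `Cc1cccc2cc(C(=O)O)cnc12`: in this assay compound 3 gives only a limit, > 25 mg/kg.

Compound 2 differs from compound 1 by methyl in place of hydrogen on an aromatic carbon. Both values are limits, one at the limit of > 20 mg/kg in this assay, at which 1 of the 3 values shown sits, and the other at the limit of > 25 mg/kg in this assay, at which 2 of the 3 values shown sit, and the step that the two limits leave unreadable from compound 1 to compound 2 stays unreadable. How the core of compound 1 and the core of compound 3 differ is not broken down here.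

Compound 4 `Cc1ccc2cc(C(=O)O)cnc2c1C` has not been measured. It differs from compound 3 by methyl in place of hydrogen on an aromatic carbon. This is the same kind of change as that from compound 1 to compound 2, but here the place is also ortho to a methyl group (1 heavy atom), which the earlier place was not. Given that compound 3 sits at the limit of > 25 mg/kg in this assay, at which 2 of the 3 values shown sit, the step from compound 3 to compound 4 is expected to be a step that the limit leaves unreadable from compound 3 to compound 4. Compound 4 is expected to give about 30 mg/kg, most likely again only a limit, somewhere between 10 mg/kg and 100 mg/kg.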

Compound 4, minimum effective dose: 50 mg/kg
The estimate for compound 4 lay 1.7-fold (0.22 log units) below the measured number; the measured number falls inside the stated range.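

No step can be read from compound 3 to compound 4, since compound 3 stands only at a limit: the limit of > 25 mg/kg in this assay, at which 2 of the 4 values shown sit. The compounds shown leave open how methyl in place of hydrogen on an aromatic carbon shifts the minimum effective dose in either core.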